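From vinylamino to diethylamino on a shared core

A few compounds are considered here, and "the series" means these few. Any claim that something is new, unique, unknown or untested is made for them only; others in the source may bear on it.

Compound 1 `CCNC(=O)c1noc(-c2cc(C(C)C)c(O)cc2O)c1-c1cc(COCC(=O)OC)no1` gives 262 nM in a functional assay on HCT-116 cells (Homo sapiens) for inhibition; a higher number here means a weaker inhibitor, a lower number a stronger inhibitor
Compound 2 `CCCNCc1cc(-c2c(C(=O)NCC)noc2-c2cc(C(C)C)c(O)cc2O)on1` gives 117 nM
Compound 3 `C=CNCc1cc(-c2c(C(=O)NCC)noc2-c2cc(C(C)C)c(O)cc2O)on1` gives 121 nM

Compound 3 stands level with compound 2, since the step of a 1.0-fold higher number from compound 2 to compound 3 (0.01 log units; within the scatter) lies within the scatter. Both have lower numbers than compound 1, which makes them the stronger inhibitors of that pair of comparisons.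

The next compound, compound 4 `CCNC(=O)c1noc(-c2cc(C(C)C)c(O)cc2O)c1-c1cc(CN(CC)CC)no1`, has diethylamino in place of vinylamino on a saturated chain carbon bound to an aromatic carbon.

Going by the values given here, three measured steps bear on this change. Putting an amino group where (methoxycarbonyl)methoxy stood gave a 2.2-fold lower number from compound 1 to compound 2 (0.35 log units; beyond the scatter) and also a 2.2-fold lower number from compound 1 to compound 3 (0.34 log units; beyond the scatter), two modest steps in the same direction. Compound 4 keeps an amino group at that place. The closest parallel is the swap of vinyl for propyl on the amine nitrogen, which gave a 1.0-fold higher number from compound 2 to compound 3 (0.01 log units; within the scatter) and so showed nothing beyond the scatter. Among the compounds with values here, no measured step makes this exact exchange, so the evidence is indirect.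

In this assay the expected step is a 1.0-fold higher number from compound 3 to compound 4 (0.01 log units; within the scatter) and it should stay within the scatter, with no firm direction. For compound 4 the estimate is 125 nM within an expected range of 55 nM to 280 nM in this measurement.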

Compound 4, half-maximal inhibitory concentration: 38 nM
For compound 4 the middle estimate is 3.3-fold (0.52 log units) above the measured one; the whole stated range lies above it.
By their numbers in this assay, from the lowest: compound 4; then compounds 2 and 3 (each within the scatter of the next); then compound 1.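

In this assay, the exact group on the amine at this place turns out to matter: compounds 2 and 3 stood level, yet diethylamino gives a clear further drop (a 3.2-fold lower number from compound 3 to compound 4 (0.50 log units; beyond the scatter); a 3.1-fold lower number from compound 2 to compound 4 (0.49 log units; beyond the scatter)). Having an amino group in place of (methoxycarbonyl)methoxy therefore does not set the number alone, and the whole exchange for diethylamino amounts to the largest step in this set (a 6.9-fold lower number from compound 1 to compound 4 (0.84 log units; beyond the scatter)). No evidence in hand explains why this amine stands apart from the other two.

The compounds shown leave open what separates diethylamino from vinylamino: the group that enters has more heavy atoms and no hydrogen-bond donor, and these two differences arrive together in a single exchange. Dimethylamino, dipropylamino or a ring amine such as piperidine on the same saturated chain carbon would show whether the trend continues and whether the two chains on the nitrogen need to be separate and ethyl in length.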